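From Methoxy to Methylsulfanyl on One Aromatic Carbon

This account rests on a few compounds, and the source may have more. Where it says the series, first, only, none or still open, it means among the compounds named here.

Of the compounds shown here, two sharing one core have numbers so far: compound 1 (`CCc1ccc(-c2nc3ccccn3c2Sc2ccccc2)cc1`) and compound 2 (`COc1ccc(-c2nc3ccccn3c2Sc2ccccc2)cc1`). In a functional assay on HepG2 cells (Homo sapiens) for inhibition, read by MTT assay, with a stated time of 48 h (on this read-out lower numbers stand for stronger inhibition and higher numbers for weaker inhibition), compound 1 gives 50200 nM and compound 2 gives 54200 nM. Among the measured compounds shown here, compound 2 therefore stands within the scatter of compound 1, the only other compound measured, and the two cannot be ranked.

The next compound is compound 3 (`CSc1ccc(-c2nc3ccccn3c2Sc2ccccc2)cc1`), which has methylsulfanyl in place of methoxy on an aromatic carbon, para to a large group. This turns 4-methoxyphenyl into 4-(methylsulfanyl)phenyl: methylsulfanyl in place of methoxy on an aromatic carbon.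

For the measured compounds named here, only one measured step bears on this change, methoxy in place of ethyl on an aromatic carbon, and it stays within the scatter: a 1.1-fold higher number from compound 1 to compound 2 (0.03 log units; within the scatter). Going by the values given here, no measured compound carries methylsulfanyl, so this single step is thin support. On that basis, no step beyond the scatter is expected in this assay, and no direction can be named. The expected step is a 1.1-fold lower number from compound 2 to compound 3 (0.04 log units; within the scatter). Compound 3 is estimated at 50000 nM, with an expected range from 25000 nM to 100000 nM.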

Compound 3, half-maximal inhibitory concentration: 7600 nM
Estimate against measurement, compound 3: 6.6-fold (0.82 log units) above; the whole stated range lies above it.
By their numbers in this assay, from the lowest: compound 3; then compounds 1 and 2 (each within the scatter of the next).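

In this assay the group on this aromatic carbon, para to a large group, proves able to shift the number: the earlier pair of methoxy and ethyl could not be told apart, yet methylsulfanyl gives a 7.1-fold lower number from compound 2 to compound 3 (0.85 log units; beyond the scatter) and also a 6.6-fold lower number from compound 1 to compound 3 (0.82 log units; beyond the scatter). Both steps lie beyond the scatter, so compound 3 is the most potent of the three compounds shown, and among the three groups seen at this place only methylsulfanyl stands apart. The exchange from methoxy keeps the count of heavy atoms and of hydrogen-bond acceptors and replaces one oxygen with one sulfur, but nothing available accounts for the step.

From the compounds shown here alone, whether the gain is particular to methylsulfanyl or extends to a longer chain such as ethylsulfanyl, to methylsulfinyl or methylsulfonyl, or to an amine at the same place stays open. Going by these compounds, all three compounds share one core and were read on one cell line, so it also remains open whether the step would hold on another core or in other cells.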